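The compounds below may be only part of what the source reports. "The series", "measured", "known", "first", "only" and "open" are said of these compounds alone.

Working notes on the series.

Three compounds of the shared core have numbers in a physicochemical assay for solubility, read by spectrophotometry, in phosphate buffer, with a stated time of 18 h, at pH 7.4; on this read-out higher numbers stand for higher solubility and lower numbers for lower solubility. Compound 1 `CCc1ccc(-c2nc3c(c(C)nn3-c3ccccc3)c(-c3ccccc3C#N)c2C#N)cc1` gives 2400 nM in this assay. Going by the values given here, compound 2 `CCc1ccc(-c2nc3c(c(C)nn3-c3ccccc3)c(-c3ccccc3OC(F)(F)F)c2C#N)cc1` gives 9900 nM, and the one measured step, a 4.1-fold higher number from compound 1 to compound 2 (0.62 log units; beyond the scatter), is the only one in hand. Compound 3 `Cc1ccc(-c2nc3c(c(C)nn3-c3ccccc3)c(-c3ccccc3O)c2C#N)cc1` gives 26000 nM and stands highest of the three, with compound 2 nearest and compound 1 furthest, both gaps beyond the scatter.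

Compound 4 `Cc1nn(-c2ccccc2)c2nc(-c3ccc(I)cc3)c(C#N)c(-c3ccccc3O)c12` is the next member, not yet measured in this assay. It differs from compound 3 in one place: iodo in place of methyl on an aromatic carbon, on an aromatic carbon of a six-membered aromatic ring of carbon only, para to a large group; cut one bond further out, 4-methylphenyl becomes 4-iodophenyl. Among the compounds with values here, the step from compound 1 to compound 2 concerns a different ring and a different pair of groups, so it does not bear on this change; no measured step does. With nothing to lean on, the expectation for compound 4 is a modest fall, a 2.6-fold lower number from compound 3 to compound 4 (0.41 log units; beyond the scatter), carrying more uncertainty than usual. Compound 4 is therefore estimated at 10000 nM in this assay, within 3000 nM to 30000 nM.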

Compound 4, solubility: 1500 nM
The estimate for compound 4 lay 6.7-fold (0.82 log units) above the measured number; measured number below the stated range.
By their numbers in this assay, from the lowest: compounds 4 and 1 (each within the scatter of the next); then compound 2; then compound 3.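

In this assay, the change on the six-membered aromatic ring of carbon only, para to a large group, gives a large step (a 17-fold lower number from compound 3 to compound 4 (1.24 log units; beyond the scatter)), so the number at this place is sensitive to the exchange of a single substituent, methyl for iodo. Going by these compounds alone, the only earlier step (a 4.1-fold higher number from compound 1 to compound 2 (0.62 log units; beyond the scatter)) concerned a different ring, which makes this the first direct reading of this position, and it shows that a change here can be large. Nothing in hand bears on what lies behind the fall.

On these data alone, whether the fall is particular to iodo or would also appear with chloro, bromo or methoxy at this place remains open. Also open, as far as these compounds go, is whether an amine or a carboxylic acid there would raise the number above that of compound 3.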